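This account rests on a few compounds, and the source may have more. Where it says the series, first, only, none or still open, it means among the compounds named here.

Of the compounds shown here, two have so far been measured in a functional assay on SK-OV-3 cells (Homo sapiens) for cytotoxicity; on this read-out lower numbers stand for an effect already at smaller amounts and higher numbers for an effect only at larger amounts of compound. Compound 1, `C#C/C=C\CCCCCCCCCCCCCCC/C=C\CCCC/C=C\CCCCC#C[C@@H](O)C#CCCCCCC/C=C/[C@H](O)C#C`, gives 2.2 ug/mL in this assay. Compound 2, `C#C/C=C\CCCCCCCCCCCCCC/C=C\CCC/C=C/C(O)CCCCC#C[C@H](O)C#CCCCCCC/C=C/[C@H](O)C#C`, gives 1.9 ug/mL in this assay. These two numbers lie within the usual scatter of each other, so compound 1 cannot be set apart from compound 2 on this read-out; it stands simply as one of two measured points that agree.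

Compound 3, `C#C/C=C\CCCCCCCCCCCCC/C=C\CCCC/C=C\CCCCC#C[C@@H](O)C#CCCCCCC/C=C/[C@H](O)C#C`, has not yet been measured. It differs from compound 1 in a single place: a group of 4 heavy atoms (4 carbon; no ring) in place of a group of 6 heavy atoms (6 carbon; no ring), on a saturated chain carbon, ten or more bonds along the chain from a double-bonded chain carbon. The change sits at the place just described and touches no hydrogen-bond donor or acceptor. Among the measured compounds shown here, no measured pair shows what such a change does, so there is no step to lean on, and the expectation must rest on the closeness of the two measured values alone. The step from compound 1 to compound 3 is expected to be none beyond the scatter, as no change at the digits printed from compound 1 to compound 3 (within the scatter) describes. Compound 3 is estimated at 2.2 ug/mL, with a range from 1.1 ug/mL to 4.4 ug/mL.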

Compound 3, concentration for half-maximal effect: 4.4 ug/mL
The estimate for compound 3 lay 2.0-fold (0.30 log units) below the measured number; the range from low to high includes it.
By their numbers in this assay, from the lowest: compounds 2, 1 and 3 (each within the scatter of the next, the first and the last beyond it).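

Among the compounds shown here, the first step at this position is a 2.0-fold higher number from compound 1 to compound 3 (0.30 log units; within the scatter) in this assay, and it stays within the usual scatter of repeated measurements. For the compounds shown here, the earlier pair, compound 1 and compound 2, differs in more than one place, so only this pair isolates the effect of a group of 4 heavy atoms (4 carbon; no ring) in place of a group of 6 heavy atoms (6 carbon; no ring), on a saturated chain carbon, ten or more bonds along the chain from a double-bonded chain carbon: here, the swap gives no difference that can be told apart from measurement noise, although a single pair cannot rule out a small real effect. No further measurement accompanies this pair, so the data offer no explanation of how this part of the chain relates to the read-out.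

The compounds shown leave open whether this tolerance extends to a much longer chain or a much shorter one at the same place. They also leave open what an amine or a carboxylic acid at that place would do, since every group compared here is made of carbon alone.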